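Chloro in place of hydrogen: one step, two cores

The source may report more compounds than this note shows. Statements on the series, on what has been measured and on what is new or still open speak of the compounds shown alone.

Compound 1 `Cc1cc(C)cc(S(=O)(=O)n2c(SCC(=O)Nc3ccccc3Cl)nc3ccccc32)c1` in an ADME assay on MT4 cells (Homo sapiens) for cytotoxicity (a higher number here means that more compound is tolerated, a lower number that less compound is tolerated), gives 107000 nM. Compound 2 `Cc1cc(C)cc(S(=O)(=O)n2c(SCC(=O)Nc3ccccc3Cl)nc3ccc(Cl)cc32)c1` in this assay gives 99300 nM. The step of a 1.1-fold lower number from compound 1 to compound 2 (0.03 log units; within the scatter) comes with the change (chloro in place of hydrogen on an aromatic carbon).

Compound 3 `Cc1cc(C)cc(Cn2c(SCC(=O)Nc3ccccc3[N+](=O)[O-])nc3ccccc32)c1` carries a different core; the difference between the two cores is not broken down here. In this assay compound 3 gives 194000 nM, and its values against compound 1 and against compound 2 lie within the scatter of each other, so no order among the three is read from them.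

Compound 4 `Cc1cc(C)cc(Cn2c(SCC(=O)Nc3ccccc3[N+](=O)[O-])nc3ccc(Cl)cc32)c1` is not yet measured. It differs from compound 3 by chloro in place of hydrogen on an aromatic carbon, the same change as from compound 1 to compound 2, made at the same place of the fused ring. For the measured compounds named here, the step of a 1.1-fold lower number from compound 3 to compound 4 (0.03 log units; within the scatter) is expected to match a 1.1-fold lower number from compound 1 to compound 2 (0.03 log units; within the scatter), because the one measured instance of this change, a 1.1-fold lower number from compound 1 to compound 2 (0.03 log units; within the scatter), stayed within the scatter. Compound 4 is therefore estimated at 180000 nM in this assay, with a range from 100000 nM to 350000 nM.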

Compound 4, half-maximal cytotoxic concentration: 131000 nM
The estimate for compound 4 lay 1.4-fold (0.14 log units) above the measured number; low and high end bracket the measured number.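

On the second core, chloro in place of hydrogen on an aromatic carbon gives in this assay a 1.5-fold lower number from compound 3 to compound 4 (0.17 log units; within the scatter) and so sits alongside the earlier step without a readable difference: the same change on two cores in this assay, a 1.1-fold lower number (0.03 log units; within the scatter) from compound 1 to compound 2 and a 1.5-fold lower number (0.17 log units; within the scatter) from compound 3 to compound 4, 1.4-fold (0.14 log units) apart, within the scatter of two such steps. Across these two cores the change therefore carries over as a step that stays inside the scatter, and nothing measured here separates its effect on one core from its effect on the other. Neither step can be given a real size or direction, and two cores are too few to say how the change would read on a third.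

Chloro is the only group shown at this place of the fused ring, so whether fluoro, methoxy, an amine or a carboxylic acid there would also stay inside the scatter remains open. Also open, going by these compounds, is whether the chloro step stays this small on a core with a longer chain, or in any other assay.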